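A few compounds are considered here, and "the series" means these few. Any claim that something is new, unique, unknown or untested is made for them only; others in the source may bear on it.

Of the compounds shown here, three sharing one core have been tested in a functional assay (cardiac atrium) for agonist activity, with Cavia porcellus as the target; on this read-out lower numbers stand for an effect already at smaller amounts and higher numbers for an effect only at larger amounts of compound. Compound 1 `CC1=NC(C)=C([N+](=O)[O-])C(c2cccc(C)n2)/C1=C(/O)OC(C)C` gives 1810 nM, compound 2 `CCO/C(O)=C1/C(C)=NC(C)=C([N+](=O)[O-])C1c1cccc(C)n1` gives 12300 nM, and compound 3 `CC1=NC(C)=C([N+](=O)[O-])C(c2ncccc2C)/C1=C(/O)OC(C)C` gives 9970 nM. Compound 3 thus lies within the scatter of compound 2, and both sit well beyond the scatter from compound 1, which has the lowest number.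

The next compound, compound 4 `CC1=NC(C)=C([N+](=O)[O-])C(c2cccc(Cl)n2)/C1=C(/O)OC(C)C`, differs from compound 3 in one group: 6-chloropyridin-2-yl in place of 3-methylpyridin-2-yl on a saturated ring carbon. In words, 6-chloropyridin-2-yl takes the place of 3-methylpyridin-2-yl on a saturated ring carbon, next to the ring atom that bears a nitro group.

Two measured steps are available. One, a 6.8-fold higher number from compound 1 to compound 2 (0.83 log units; beyond the scatter), comes from a change elsewhere in the molecule, so it offers little guidance here. The other, a 5.5-fold higher number from compound 1 to compound 3 (0.74 log units; beyond the scatter), is a swap on this same ring carbon, from 6-methylpyridin-2-yl to 3-methylpyridin-2-yl. For the measured compounds named here, the group in compound 4 resembles the one in compound 1 by name, with chlorine in place of methyl, but no compound with chlorine has been measured yet. A move back towards a lower number is therefore expected, of modest size and probably not quite the full way to compound 1. The expected step is a 3.6-fold lower number from compound 3 to compound 4 (0.55 log units; beyond the scatter). In this assay, compound 4 is estimated at 2800 nM, with an expected range from 900 nM to 8500 nM.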

Compound 4, half-maximal effective concentration: 5960 nM
Estimate against measurement, compound 4: 2.1-fold (0.33 log units) below; the range from low to high includes it.
By their numbers in this assay, from the lowest: compound 1; then compounds 4, 3 and 2 (each within the scatter of the next, the first and the last beyond it).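

In this assay, putting 6-chloropyridin-2-yl in place of 3-methylpyridin-2-yl on this saturated ring carbon gives a 1.7-fold lower number from compound 3 to compound 4 (0.22 log units; within the scatter), so these two groups cannot be told apart here. The more informative comparison is with compound 1, where chloro in place of methyl on an aromatic carbon gives a 3.3-fold higher number from compound 1 to compound 4 (0.52 log units; beyond the scatter); the low number of compound 1 therefore does not carry over to a group that merely has a different substituent at the same place on the pyridine, and among the three groups tried on this carbon, only 6-methylpyridin-2-yl gives it. Nothing available explains why methyl and chloro differ here.

As far as these compounds go, it remains open whether a group such as plain pyridin-2-yl, 6-methoxypyridin-2-yl or 6-aminopyridin-2-yl on this carbon would match compound 1, fall in with compounds 3 and 4, or reach a lower number still. From the compounds shown here alone, it is also open whether chloro in place of methyl would give a step of similar size on the core of compound 2, which differs from compound 1 elsewhere in the molecule.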